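Replacing butyl in compound 3

This account rests on a few compounds, and the source may have more. Where it says the series, first, only, none or still open, it means among the compounds named here.

Measured in a functional assay on a cell-free system (plasma, Homo sapiens), with a stated time of 3 min; on this read-out higher numbers stand for weaker inhibition and lower numbers for stronger inhibition:
compound 1 `O=C(NCc1cc(Cl)ccc1-n1cnnn1)[C@@H]1[C@@H]2C[C@@H]2CN1C(=O)[C@H](O)Cc1ccccn1`: 1700 nM
compound 2 `O=C(NCc1cc(Cl)ccc1-n1cnnn1)[C@@H]1C[C@@H]2C[C@@H]2N1C(=O)[C@H](O)C1CCCCC1`: 600 nM
compound 3 `CCCC[C@@H](O)C(=O)N1C[C@H]2C[C@H]2[C@H]1C(=O)NCc1cc(Cl)ccc1-n1cnnn1`: 750 nM

Compound 3, at 750 nM, lies within the scatter of compound 2 and has a lower number than compound 1. Compound 4 `COC(C)(C)[C@@H](O)C(=O)N1C[C@H]2C[C@H]2[C@H]1C(=O)NCc1cc(Cl)ccc1-n1cnnn1` carries 1-methoxy-1-methylethyl in place of butyl on a saturated chain carbon bound to a carbonyl carbon and an oxygen on a saturated carbon. For the measured compounds named here, only one measured step bears on this change: a 2.3-fold lower number from compound 1 to compound 3 (0.36 log units; beyond the scatter). That step is modest and involves other groups, so no clear direction can be expected in this assay. The expected outcome is a 1.1-fold higher number from compound 3 to compound 4 (0.03 log units; within the scatter), which is no step beyond the scatter. For compound 4 the estimate is 800 nM, with an expected range of 280 nM to 2300 nM.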

Compound 4, half-maximal inhibitory concentration: 1000 nM
Estimate against measurement, compound 4: 1.3-fold (0.10 log units) below; measured number inside the range.
By their numbers in this assay, from the lowest: compounds 2, 3, 4 and 1 (each within the scatter of the next, the first and the last beyond it).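

In this assay, 1-methoxy-1-methylethyl in place of butyl gives no step beyond the scatter (a 1.3-fold higher number from compound 3 to compound 4 (0.12 log units; within the scatter)), so this position accepts the added oxygen without a clear shift in the number. Against the (pyridin-2-yl)methyl group the step also stays within the scatter (a 1.7-fold lower number from compound 1 to compound 4 (0.23 log units; within the scatter)), so compound 4 does not separate clearly from either neighbour. Nothing available explains this result. The compounds shown leave open whether an amine, a carboxylic acid or a longer chain on this carbon would give a step beyond the scatter.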